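The compounds below may be only part of what the source reports. "The series", "measured", "known", "first", "only" and "open" are said of these compounds alone.

Measured compounds:
- compound 1, `COC(=O)c1cc(-c2cccc(NC(=O)c3ccc(C4OC4C(=O)c4ccc(Cl)cc4)cc3)c2)on1`: > 20 ug/mL
- compound 2, `COC(=O)c1cc(-c2cccc(NC(=O)c3ccc(OCc4ccc(Cl)cc4)cc3)c2)on1`: > 80 ug/mL
- compound 3, `CCCOc1ccc(C(=O)/C=C/c2ccc(C(=O)Nc3cccc(-c4cc(C(=O)OC)no4)c3)cc2)cc1`: > 40 ug/mL

All three values come from an ADME assay on Vero cells (Chlorocebus sabaeus) for cytotoxicity, read by MTT assay, with a stated time of 72 h; a higher number here means that more compound is tolerated, a lower number that less compound is tolerated. For compound 2 the result of > 80 ug/mL is only a limit of the assay, not a number. The same holds for compound 1, whose > 20 ug/mL is a limit. For compound 3 the > 40 ug/mL is likewise a limit. So compound 2 stands at a limit, and the two other values shown are limits as well; the single step from compound 1 to compound 2, a step that the two limits leave unreadable from compound 1 to compound 2, cannot be read in size for that reason.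

Compound 4, `COC(=O)c1cc(-c2cccc(NC(=O)c3ccc(/C=C/C(=O)c4ccc(Cl)cc4)cc3)c2)on1`, has not been measured yet. Compared with compound 2 it carries 2-((4-chlorophenyl)carbonyl)ethenyl in place of (4-chlorobenzyl)oxy on an aromatic carbon. For the measured compounds named here, no measured step involves this exact exchange, and the one step recorded, from compound 1 to compound 2, is unreadable. What can be said is that compound 3, which also carries a double bond joined to a carbonyl, and compound 1 are both reported only as limits in this assay. A step beyond the scatter is therefore not expected in either direction, and a limit is the likeliest outcome for compound 4 too. Compound 4 is expected to give about 60 ug/mL, within a range from 20 ug/mL to 160 ug/mL. This estimate corresponds to an expected step of an at least 1.3-fold lower number from compound 2 to compound 4 (0.12 log units; that floor lies within the scatter).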

Compound 4, half-maximal cytotoxic concentration: > 50 ug/mL
Compound 4 ended at the assay's limit (the forecaster's own chance of this, stated with the estimate: 80%); the middle value is on the limit's open side.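

In this assay compound 4 gives > 50 ug/mL and this is a limit, not a number. Compound 1, compound 2 and compound 3 also stand at limits, so none of their steps to compound 4 can be read in size. The compounds shown leave open where the real half-maximal cytotoxic concentration of each compound lies, and whether any of these exchanges changes it.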